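This account rests on a few compounds, and the source may have more. Where it says the series, first, only, none or still open, it means among the compounds named here.

Compound 3 `CC(=O)c1cccc(C#Cc2cc(F)cc(C#N)c2)n1` gives 64 nM in an assay on membranes from brain (strain Sprague-Dawley) for displacement of a labelled ligand from metabotropic glutamate receptor 5 (Rattus norvegicus), read by scintillation counting, with a stated time of 60 min (on this read-out higher numbers stand for weaker inhibition and lower numbers for stronger inhibition), the highest of the three numbers shown. Compound 2 `N#Cc1cc(F)cc(C#Cc2cccc(F)n2)c1` stands nearest with 41 nM, and the step of a 1.6-fold higher number from compound 2 to compound 3 (0.19 log units; within the scatter) lies within the scatter. Compound 1 `COc1cc(C#N)cc(C#Cc2cccc(C)n2)c1`, which carries a methyl on the same ring nitrogen-bearing ring and a methoxy on the other ring, gives 1.29 nM in this assay. Compound 4 `Cc1cccc(C#Cc2cc(F)cc(C#N)c2)n1` differs from compound 3 by methyl in place of acetyl on an aromatic carbon. For the measured compounds named here, no measured step covers a methyl entering for an acetyl; the only step at that position, from fluoro to acetyl, was within the scatter, while compound 1 with its methyl shows a far lower number than compound 2 or compound 3. Compound 4 is therefore expected to give a lower number than compound 3, a step of a 6.4-fold lower number from compound 3 to compound 4 (0.81 log units; beyond the scatter), with an estimate of 10 nM and a range from 2 nM to 50 nM.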

Compound 4, inhibition constant: 0.67 nM
Compound 4: the middle estimate sits 15-fold (1.17 log units) above what was measured; measured number below the stated range.
By their numbers in this assay, from the lowest: compounds 4 and 1 (each within the scatter of the next); then compounds 2 and 3 (each within the scatter of the next).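

On the core shared by compound 2, compound 3 and compound 4, this assay gives a 96-fold lower number from compound 3 to compound 4 (1.98 log units; beyond the scatter) and a 61-fold lower number from compound 2 to compound 4 (1.79 log units; beyond the scatter), so methyl next to the ring nitrogen stands well apart from both acetyl and fluoro. With methyl at this place, the exchange on the other ring gives a 1.9-fold lower number from compound 1 to compound 4 (0.28 log units; within the scatter), which lies within the scatter. No available evidence explains why methyl differs so sharply from the other two groups. From the compounds shown here alone, whether an ethyl, a longer chain or an amine at this place would behave like methyl or like acetyl remains open.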